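Adding Chlorine to the Benzyl Group of Compound 3

The source may report more compounds than this note shows. Statements on the series, on what has been measured and on what is new or still open speak of the compounds shown alone.

Three compounds were tested in a functional assay on the whole organism (artery, strain albino) with Rattus norvegicus as the target, with a stated time of 360 min, at a dose of 10 mg/kg by the oral route; a lower number here means less inhibition, a higher number more inhibition at the dose given (going by the name of the read-out). Compound 1 `COc1ccc(C2N=C(SCc3ccccc3)NC(C)=C2C(=O)Nc2ccc(F)cc2)cc1OC` gives 3.6%. Compound 2 `COc1ccc(C2N=C(SCc3cccc(Cl)c3)NC(C)=C2C(=O)Nc2ccc(F)cc2)cc1OC` gives 20.1%, and compound 3 `CC1=C(C(=O)Nc2ccc(F)cc2)C(c2ccc([N+](=O)[O-])cc2)N=C(SCc2ccccc2)N1` gives 38.7%. Compound 3 therefore stands highest of the three, with compound 2 nearest and compound 1 furthest away.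

Compound 4 `CC1=C(C(=O)Nc2ccc(F)cc2)C(c2ccc([N+](=O)[O-])cc2)N=C(SCc2cccc(Cl)c2)N1` has not yet been measured. It differs from compound 3 in one place: chloro in place of hydrogen on an aromatic carbon.

Among the compounds with values here, one measured step bears directly on this change. The same replacement, made on the benzyl group of compound 1 to give compound 2, produced a number 16.5 percentage points higher from compound 1 to compound 2 (beyond the scatter). The other step, a number 35.1 percentage points higher from compound 1 to compound 3 (beyond the scatter), concerns a different part of the molecule and does not speak to the change at hand.

On that basis, a rise of similar size is expected, a number 15.3 percentage points higher from compound 3 to compound 4 (beyond the scatter). Compound 4 is estimated to give 54% in this assay, with a plausible range from 36% to 70%.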

Compound 4, a percentage reported as inhibition, in the whole organism at one dose (the size of the read-out at that dose, not a potency): 21.1%
Compound 4: the middle estimate sits 32.9 percentage points above what was measured; the measured number lies below the stated range.
By their numbers in this assay, from the lowest: compound 1; then compounds 2 and 4 (each within the scatter of the next); then compound 3.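

On the core carrying 4-nitrophenyl, chloro in place of hydrogen on the benzyl group gives a number 17.6 percentage points lower from compound 3 to compound 4 (beyond the scatter) in this assay, so the direction of this change depends on the rest of the molecule: the same change on two cores in this assay, a number 16.5 percentage points higher (beyond the scatter) from compound 1 to compound 2 and a number 17.6 percentage points lower (beyond the scatter) from compound 3 to compound 4, 34.1 percentage points apart, beyond the scatter of two such steps. With 3-chlorobenzyl in place, 4-nitrophenyl in place of 3,4-dimethoxyphenyl gives a number 1 percentage points higher from compound 2 to compound 4 (within the scatter), so that change does not carry over either: the same change on two cores in this assay, a number 35.1 percentage points higher (beyond the scatter) from compound 1 to compound 3 and a number 1 percentage points higher (within the scatter) from compound 2 to compound 4, 34.1 percentage points apart, beyond the scatter of two such steps. Across these four compounds, the two changes therefore do not act as separate, additive contributions, since what each one does depends on the other.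

From the compounds shown here alone, it remains open whether this dependence is specific to chloro or also appears with fluoro, methyl or methoxy on the benzyl ring. Going by these compounds, it is equally open how a plain phenyl or a 4-cyanophenyl in place of 4-nitrophenyl would behave with each benzyl group.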